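The source may report more compounds than this note shows. Statements on the series, on what has been measured and on what is new or still open speak of the compounds shown alone.

Working notes on the series.

Three compounds have a number in a functional assay, with a stated time of 10 min (on this read-out higher numbers stand for weaker inhibition and lower numbers for stronger inhibition), so far. Compound 1 `CCOC(=O)c1cnn(-c2nc(-c3ccccc3F)c(C#N)c(=O)n2C)c1N` gives 86 ug/mL and stands highest of the three. Compound 2 `COc1cccc(-c2nc(NN)n(C)c(=O)c2C#N)c1OC` gives 36 ug/mL, and compound 3 `Cn1c(NN)nc(-c2ccccc2O)c(C#N)c1=O` gives 30 ug/mL; both of these gaps to compound 1 lie beyond the usual scatter, so compound 1 is the weakest inhibitor among the measured set. Within the data shown here, compounds 2 and 3 differ from compound 1 in more than one place, so no single step between measured compounds can be read off; the numbers for compounds 2 and 3 themselves lie within the scatter of each other.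

Compound 4 `CCOC(=O)c1cnn(-c2nc(-c3cccc(O)c3O)c(C#N)c(=O)n2C)c1N` is not yet measured in this assay. It differs from compound 1 in one place: 2,3-dihydroxyphenyl in place of 2-fluorophenyl on an aromatic carbon. Among the measured compounds shown here, the only hint available is that compound 3, which carries a hydroxyphenyl, gives the lowest number so far, while the rest of compound 3 also differs from compound 1, so the hint is weak.

The expectation is a modest move toward stronger inhibition, a step from compound 1 to compound 4 of a 1.7-fold lower number from compound 1 to compound 4 (0.24 log units; within the scatter), lying near the edge of the scatter. Compound 4 is therefore estimated at 50 ug/mL, with a range from 22 ug/mL to 115 ug/mL.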

Compound 4, half-maximal inhibitory concentration: 53 ug/mL
For compound 4 the middle estimate is 1.1-fold (0.03 log units) below the measured one, and the stated range covers the measured number.
By their numbers in this assay, from the lowest: compounds 3, 2, 4 and 1 (each within the scatter of the next, the first and the last beyond it).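

Among these compounds, this is the first step that can be read in one place: in this assay, 2,3-dihydroxyphenyl in place of 2-fluorophenyl, on the aromatic carbon ortho to a cyano group, gives a 1.6-fold lower number from compound 1 to compound 4 (0.21 log units; within the scatter), and the read-out therefore cannot separate the two groups. Among the compounds shown here, on the core of compound 1, this position thus accepts a change from a ring with 0 hydrogen-bond donors and 0 hydrogen-bond acceptors to one with 2 of each, with no shift that stands clear of repeat-measurement noise, which the earlier compounds could not show. No supporting data on the compounds bear on this result.

From the compounds shown here alone, whether either hydroxyl counts on its own remains open, as does the outcome at this position for a phenyl ring carrying an amine or a carboxylic acid, or for a ring-free group such as a longer alkyl chain. Steps linking compound 2 or compound 3 to compound 1 or compound 4 cannot be read, since those pairs differ in more than one place.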